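This account rests on a few compounds, and the source may have more. Where it says the series, first, only, none or still open, it means among the compounds named here.

Measured so far in a functional assay for inhibition, with Homo sapiens as the target; on this read-out higher numbers stand for an effect only at larger amounts of compound and lower numbers for an effect already at smaller amounts:
Compound 1, `CCCC(=O)Nc1ccc(C2=NNC(=O)CC2)cc1`, gives 1.44 ug/mL.
Compound 2, `CCCCC(=O)Nc1ccc(C2=NNC(=O)CC2)cc1`, gives 2.64 ug/mL.
Compound 3, `CC1CC(c2ccc(NC(=O)CCl)cc2)=NNC1=O`, gives 21.9 ug/mL.

Compound 1 and compound 2 share a core and differ by one change, (methyl in place of hydrogen on a saturated chain carbon, three bonds along the chain from a carbonyl carbon); this gives the step of a 1.8-fold higher number from compound 1 to compound 2 (0.26 log units; within the scatter). Compound 3 carries a different core, and how its core differs from that of compound 1 is not broken down here; its number is the highest of the three.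

Compound 4, `CC(Cl)C(=O)Nc1ccc(C2=NNC(=O)C(C)C2)cc1`, has not yet been measured. It differs from compound 3 by methyl in place of hydrogen on a saturated chain carbon bound to a carbonyl carbon and a chlorine atom. This is the same kind of change as from compound 1 to compound 2, but the place differs: there the methyl entered three bonds along the chain from a carbonyl carbon, here it enters on a saturated chain carbon bound to a carbonyl carbon and a chlorine atom. Since the earlier step of a 1.8-fold higher number from compound 1 to compound 2 (0.26 log units; within the scatter) stayed within the scatter, a similarly small step a 1.4-fold higher number from compound 3 to compound 4 (0.14 log units; within the scatter) is expected here. Compound 4 is estimated at 30 ug/mL, between 12 ug/mL and 80 ug/mL.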

Compound 4, half-maximal effective concentration: 32.9 ug/mL
For compound 4 the middle estimate is 1.1-fold (0.04 log units) below the measured one, within the range that was stated.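

Turning chloromethyl into 1-chloroethyl gives a 1.5-fold higher number from compound 3 to compound 4 (0.18 log units; within the scatter) in this assay. The same swap of a hydrogen for a methyl thus gives steps of similar size on the two cores: the same change on two cores in this assay, a 1.8-fold higher number (0.26 log units; within the scatter) from compound 1 to compound 2 and a 1.5-fold higher number (0.18 log units; within the scatter) from compound 3 to compound 4, 1.2-fold (0.09 log units) apart, within the scatter of two such steps. For the compounds shown here, this shows only that the change made no step beyond the scatter on either core; it does not show that the same would hold on a third core, and the methyl enters at a different place in each pair.

The compounds shown leave open what a longer chain, an amine or a carboxylic acid would do in place of this methyl on the saturated chain carbon bound to a carbonyl carbon and a chlorine atom. They also leave open what a hydrogen atom in place of the chlorine atom would do on the core of compound 3.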